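This account rests on a few compounds, and the source may have more. Where it says the series, first, only, none or still open, it means among the compounds named here.

The series shares the core seen in compound 1 `O=C1/C(=C/c2cccc(C(F)(F)F)c2)CCc2c(O)cccc21`, which in a functional assay on RAW264.7 cells (Mus musculus) for inhibition (a lower number here means a stronger inhibitor, a higher number a weaker inhibitor), gives 1970 nM. Compound 2 `O=C1/C(=C/c2cccc(Br)c2)CCc2c(O)cccc21` gives 1700 nM in this assay, and compound 3 `O=C1/C(=C/c2ccccn2)CCc2c(O)cccc21` gives 740 nM. Within the data shown here, the only single-point step among the measured pairs, a 1.2-fold lower number from compound 1 to compound 2 (0.06 log units; within the scatter), stays within the scatter. Compound 3 stands at the lowest number of the three; its gaps to compound 2 and to compound 1 both lie beyond the scatter, so on the numbers shown it is the strongest inhibitor of the set.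

Compound 4 `O=C1/C(=C/c2ccncc2)CCc2c(O)cccc21` differs from compound 3 by pyridin-4-yl in place of pyridin-2-yl on a double-bonded chain carbon bound to a double-bonded ring carbon. Among the measured compounds shown here, no measured step bears directly on this change: the one step available, a 1.2-fold lower number from compound 1 to compound 2 (0.06 log units; within the scatter), exchanges one group for another on an aromatic carbon, whereas here the same atoms are joined differently. The expectation for compound 4 in this assay therefore rests on compound 3 alone and carries wide bounds. A step of a 1.1-fold higher number from compound 3 to compound 4 (0.03 log units; within the scatter) is expected, with no direction beyond the scatter favoured. For compound 4 the estimated value is 800 nM, within a range of 300 nM to 2000 nM.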

Compound 4, half-maximal inhibitory concentration: 4170 nM
For compound 4 the middle estimate is 5.2-fold (0.72 log units) below the measured one, and the stated range ends below it.
By their numbers in this assay, from the lowest: compound 3; then compounds 2 and 1 (each within the scatter of the next); then compound 4.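

At the double-bonded chain carbon bound to a double-bonded ring carbon, pyridin-4-yl in place of pyridin-2-yl gives a 5.6-fold higher number from compound 3 to compound 4 (0.75 log units; beyond the scatter) in this assay, so the point of attachment of the pyridine ring matters at this position. The heavy atoms, hydrogen-bond donors and acceptors counted for the two groups are the same, so those counts do not separate them; the earlier single-point step, a 1.2-fold lower number from compound 1 to compound 2 (0.06 log units; within the scatter), with bromo in place of trifluoromethyl on an aromatic carbon, stayed within the scatter and gave no such separation. Nothing measured here accounts for the gap between pyridin-2-yl and pyridin-4-yl.

Open, as far as these compounds go, is whether pyridin-3-yl at the same carbon would read with pyridin-2-yl or with pyridin-4-yl, and whether a pyrimidin-2-yl group would keep or lose the number of compound 3. Also open, from the compounds shown here alone, is whether the step from pyridin-2-yl to pyridin-4-yl would hold with a methoxy group in place of the hydroxyl on the shared core.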